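Series notes: from compound 2 to compound 3

A few compounds are considered here, and "the series" means these few. Any claim that something is new, unique, unknown or untested is made for them only; others in the source may bear on it.

Measured so far:
- compound 1 `COc1ccc(CNc2nc(Nc3ccc(N4CCN(C)CC4)cn3)ncc2Cl)cc1`: 12900 nM
- compound 2 `CCc1ccc(Nc2nc(Nc3ccc(N4CCN(C)CC4)cn3)ncc2Cl)cc1`: 11100 nM

In a functional assay on Jurkat cells (Homo sapiens) for inhibition, read by CCK-8 assay, with a stated time of 48 h (a lower number here means a stronger inhibitor of growth, a higher number a weaker inhibitor of growth), compound 2 gives 11100 nM, a value not separated from the only other one in the series. Next to be measured is compound 3 `CC(C)c1cccc(Nc2nc(Nc3ccc(N4CCN(C)CC4)cn3)ncc2Cl)c1`, which has 3-isopropylphenyl in place of 4-ethylphenyl on a nitrogen on an aromatic ring.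

Among the measured compounds shown here, one measured step bears on this change, as it also swaps the group on that nitrogen: a 1.2-fold lower number from compound 1 to compound 2 (0.07 log units; within the scatter). This step stayed within the scatter, although it exchanged 4-methoxybenzyl for 4-ethylphenyl. For the measured compounds named here, it is thin evidence, and no measured compound carries 3-isopropylphenyl. On this basis, no step beyond the scatter is expected in this assay, though the uncertainty stays wide.

The step expected is a 1.2-fold lower number from compound 2 to compound 3 (0.09 log units; within the scatter). For compound 3 the estimated value is 9000 nM, with an expected range of 3500 nM to 20000 nM.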

Compound 3, concentration for 50% growth inhibition: 12300 nM
Beside the measured number, compound 3's estimate is 1.4-fold (0.14 log units) below it, within the range that was stated.
By their numbers in this assay, from the lowest: compounds 2, 3 and 1 (each within the scatter of the next).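

In this assay, the change at this nitrogen gives a 1.1-fold higher number from compound 2 to compound 3 (0.04 log units; within the scatter) and so adds a change in the place of the alkyl group on the phenyl ring, from 4-ethylphenyl to 3-isopropylphenyl, with no separation in the values. The comparison with the benzyl compound gives a 1.0-fold lower number from compound 1 to compound 3 (0.02 log units; within the scatter) and completes the set: compounds 1, 2 and 3 all lie within the scatter of one another, so 4-methoxybenzyl, 4-ethylphenyl and 3-isopropylphenyl are not told apart on this nitrogen in this growth read-out. No supporting data bear on why the three values stay together.

Still open, as far as these compounds go, is whether a phenyl ring carrying a carboxylic acid or a primary amine, or a short alkyl chain in place of the ring, would give a step beyond the scatter at this nitrogen. The three compounds also share the rest of their structure, so they say nothing about how the values respond to changes elsewhere on the shared core, such as replacing the methylpiperazine with a morpholine.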